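Chloro in place of bromo on the fused ring of compound 3

A few compounds are considered here, and "the series" means these few. Any claim that something is new, unique, unknown or untested is made for them only; others in the source may bear on it.

Measured so far in a functional assay on cells (Cancer cell lines, Homo sapiens) for cytotoxicity, read by sulforhodamine B assay, with a stated time of 48 h; a lower number here means a stronger inhibitor of growth, a higher number a weaker inhibitor of growth:
compound 1 `O=C1N=C(N2N=C(c3ccccc3)CC2c2ccccc2O)S/C1=C1/C(=O)Nc2ccc(Br)cc21` — 720 nM
compound 2 `CN(C)c1ccc(C2CC(c3ccccc3)=NN2C2=NC(=O)/C(=C3\C(=O)Nc4ccccc43)S2)cc1` — 3240 nM
compound 3 `CN(C)c1ccc(C2CC(c3ccccc3)=NN2C2=NC(=O)/C(=C3\C(=O)Nc4ccc(Br)cc43)S2)cc1` — 450 nM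

For the measured compounds named here, compound 3 shows the lowest of the three numbers, but the step of a 1.6-fold lower number from compound 1 to compound 3 (0.20 log units; within the scatter) stays within the scatter, so only the step of a 7.2-fold lower number from compound 2 to compound 3 (0.86 log units; beyond the scatter) separates it clearly from another compound. Compound 4 `CN(C)c1ccc(C2CC(c3ccccc3)=NN2C2=NC(=O)/C(=C3\C(=O)Nc4ccc(Cl)cc43)S2)cc1` differs from compound 3 by chloro in place of bromo on an aromatic carbon. Going by the values given here, the one measured step at this position, a 7.2-fold lower number from compound 2 to compound 3 (0.86 log units; beyond the scatter), concerns bromo against hydrogen; an exchange of one halogen for another is a smaller move, and no measured pair shows it. In this assay compound 4 is therefore expected to sit close to compound 3, with a step of a 1.4-fold higher number from compound 3 to compound 4 (0.16 log units; within the scatter) that does not go beyond the scatter. The estimate for compound 4 is 650 nM, in the range 300 nM to 1500 nM.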

Compound 4, concentration for total growth inhibition: 430 nM
Estimate against measurement, compound 4: 1.5-fold (0.18 log units) above; low and high end bracket the measured number.
By their numbers in this assay, from the lowest: compounds 4, 3 and 1 (each within the scatter of the next); then compound 2.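

In this assay, the exchange of one halogen for the other gives a 1.0-fold lower number from compound 3 to compound 4 (0.02 log units; within the scatter) and so does not separate chloro from bromo at this aromatic carbon. Chloro in place of hydrogen gives a 7.5-fold lower number from compound 2 to compound 4 (0.88 log units; beyond the scatter) and bromo in place of hydrogen gives a 7.2-fold lower number from compound 2 to compound 3 (0.86 log units; beyond the scatter), so the lower number against hydrogen now holds for two halogens, not one. No supporting data bear on this result.

Fluoro, methoxy, nitro and a carboxylic acid at this aromatic carbon remain open. Also open, as far as these compounds go, is whether chloro and bromo stay matched with 2-hydroxyphenyl in place of 4-(dimethylamino)phenyl.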